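Aryl exchange on the carbinol chain: compound 1 to compound 3

A few compounds are considered here, and "the series" means these few. Any claim that something is new, unique, unknown or untested is made for them only; others in the source may bear on it.

Compound 1 `COc1cccc(C(O)CCn2nc3c(Br)c(Br)c(Br)c(Br)c3n2)c1` carries a 3-methoxyphenyl on the saturated chain carbon that also bears the hydroxyl. In a functional assay on CCRF-CEM cells (Homo sapiens) for antiproliferative activity, read by MTT assay, with a stated time of 48 h, tested at 50 uM (a higher number here means a weaker effect of the compound at the concentration tested, a lower number a stronger effect), compound 1 gives 2%, the lowest of the two numbers recorded so far. Compound 2 `C[C@H](O)CCn1nc2c(Br)c(Br)c(Br)c(Br)c2n1` gives 42% in this assay, a gap from compound 1 that lies beyond the usual scatter, so compound 1 shows the stronger effect of the measured pair.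

Compound 3 `OC(CCn1nc2c(Br)c(Br)c(Br)c(Br)c2n1)c1ccc(Cl)cc1` is not yet measured. It differs from compound 1 in one place: 4-chlorophenyl in place of 3-methoxyphenyl on a saturated chain carbon bound to an oxygen on a saturated carbon and a saturated chain carbon. The hydroxyl, the chain and the shared core are unchanged; an aromatic ring remains on the same chain carbon. Within the data shown here, no step between two measured compounds of this kind is available, so the size of such an exchange is not known from the series itself. With the aromatic ring retained, the step of a number 4 percentage points higher from compound 1 to compound 3 (within the scatter) is expected to stay within the scatter. Compound 3 is therefore estimated at 6%, within a range from 0% to 28%.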

Compound 3, a percentage reported as activity, at one concentration (the size of the read-out at that concentration, not a potency): 0%
For compound 3 the middle estimate is 6 percentage points above the measured one; low and high end bracket the measured number.
By their numbers in this assay, from the lowest: compounds 3 and 1 (each within the scatter of the next); then compound 2.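

In this assay, among these compounds, 4-chlorophenyl in place of 3-methoxyphenyl on this chain carbon gives a number 2 percentage points lower from compound 1 to compound 3 (within the scatter), the first step that can be read directly. The read-out therefore holds with a different substituent at a different ring location, and the methoxy oxygen is not required for it in compound 3. No available measurement accounts for this outcome.

Since the group and its ring location change together and the read-out comes from one concentration, this step cannot separate the two changes or show any difference in potency. The compounds shown leave open how an unsubstituted phenyl, a basic amine or a carboxylic acid on the ring, or a longer chain between the core and the carbinol carbon would fare.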